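Swapping an aryl group for a chloropropyl chain

This account rests on a few compounds, and the source may have more. Where it says the series, first, only, none or still open, it means among the compounds named here.

Compound 1 `CC(C)(C)OC(=O)N1CCN(C(=S)SCc2cn(C[C@H](O)[C@H]3OC(=O)C(OCc4ccccc4)=C3OCc3ccccc3)nn2)CC1` gives > 100000 nM as a limit
Compound 2 `COc1ccccc1-c1cn(C[C@H](O)[C@H]2OC(=O)C(OCc3ccccc3)=C2OCc2ccccc2)nn1` gives > 100000 nM as a limit

In a functional assay on HeLa cells (Homo sapiens) for antiproliferative activity, read by MTT assay, with a stated time of 72 h (on this read-out higher numbers stand for weaker inhibition and lower numbers for stronger inhibition), compound 2 stands at > 100000 nM and this is a limit, not a number. For the measured compounds named here, the data so far show the limit of > 100000 nM in this assay, at which 2 of the 2 values shown sit, and nothing finer, so no measured step is available as a guide.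

Compound 3 `O=C1O[C@H]([C@@H](O)Cn2cc(CCCCl)nn2)C(OCc2ccccc2)=C1OCc1ccccc1` keeps the core of compound 2 but carries 3-chloropropyl in place of 2-methoxyphenyl on an aromatic carbon, and the count of that change reads 3-chloropropyl in place of 2-methoxyphenyl on an aromatic carbon in full.

A modest move towards stronger inhibition in this assay is expected, though another limit remains quite likely because the limit of > 100000 nM in this assay, at which 2 of the 2 values shown sit, is all that has been seen. The estimated step runs an at least 1.6-fold lower number from compound 2 to compound 3 (0.22 log units; that floor lies within the scatter) and is only a rough expectation. For compound 3 the estimated value is 60000 nM with an expected range from 12000 nM to 150000 nM as its span.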

Compound 3, half-maximal inhibitory concentration: 36700 nM
Compound 3: middle estimate off by 1.6-fold (0.21 log units), on the high side, and the stated range covers the measured number.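

In this assay, this position on the shared core turns out to be able to move the read-out: 3-chloropropyl in place of 2-methoxyphenyl brings an at least 2.7-fold lower number from compound 2 to compound 3 (0.43 log units; beyond the scatter). On these data alone, compound 2 gives > 100000 nM, which is a limit, so the printed step is a floor and the true size of the change stays unknown. Compound 3 is the only compound here with a real number, and the rest of what is known is still limits: the limit of > 100000 nM in this assay, at which 2 of the 3 values shown sit.

This single change removes an aromatic ring and brings in both a flexible chain and a chlorine, and the compounds shown cannot tell these parts apart. A plain propyl chain without chlorine, a longer chloroalkyl chain or a chain ending in an amine would show which part goes with the stronger inhibition.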